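Trimming the amide substituent: expected cytotoxicity of compound 4

This account rests on a few compounds, and the source may have more. Where it says the series, first, only, none or still open, it means among the compounds named here.

Compound 1 `CON=C1CCC(N(c2cc(C#CC(C)(C)C)sc2C(=O)O)C(=O)[C@H]2CC[C@H](C)CC2)CC1` gives only a limit, > 20000 nM, in an ADME assay on MT4 cells (Homo sapiens) for cytotoxicity, with a stated time of 5 days; a lower number here means that less compound is tolerated, a higher number that more compound is tolerated.
Compound 2 `C[C@H]1CC[C@H](C(=O)N(c2cc(C#CC3(C(F)(F)F)CCC3)sc2C(=O)O)[C@H]2CC[C@H](Oc3ccc(=O)[nH]n3)CC2)CC1` also gives only a limit, > 20000 nM, in this assay.
Compound 3 `CC(C)(C#Cc1cc(N(C(=O)[C@H]2CC[C@H](C)CC2)[C@H]2CC[C@H](Oc3ccc(=O)[nH]n3)CC2)c(C(=O)O)s1)C(F)(F)F` likewise gives only a limit, > 20000 nM, in this assay.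

Compound 1 therefore stands where every measured compound stands: at the limit of > 20000 nM in this assay, at which 3 of the 3 values shown sit. For the measured compounds named here, no numerical value separates the three, and the only single-point comparison among them, a step that the two limits leave unreadable from compound 2 to compound 3, concerns the substituent on the triple-bonded carbon, not the amide nitrogen.

Compound 4 `CC(C)(C)C#Cc1cc(N(CCO)C(=O)[C@H]2CC[C@H](C)CC2)c(C(=O)O)s1` differs from compound 1 at that nitrogen: a group of 3 heavy atoms (2 carbon, 1 oxygen; no ring) in place of a group of 9 heavy atoms (7 carbon, 1 nitrogen, 1 oxygen; one six-membered non-aromatic ring of carbon only), on an amide-type nitrogen. Going by the values given here, no measured step touches this position, and the one step that is measured is unreadable, so nothing in the data points to a shift in this assay in either direction; a change beyond the scatter has no support, and none is expected.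

The expectation for compound 4 in this assay is accordingly that it, too, will reach only the assay limit, which as a number is estimated at 25000 nM within 10000 nM to 60000 nM. The step this estimate implies, a step that the limit leaves unreadable from compound 1 to compound 4, is expected to be nil within the scatter.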

Compound 4, half-maximal cytotoxic concentration: > 20000 nM
Compound 4 gave a limit, no number (the forecaster's own chance of this, stated with the estimate: 85%); the middle value is on the limit's open side.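

Compound 1 and compound 4 both give only a limit in this assay, so no step can be read from compound 1 to compound 4: the limit of > 20000 nM in this assay, at which 4 of the 4 values shown sit.

The compounds shown leave open what concentration any of the four would reach as an actual number in this assay, and whether any change at the amide-type nitrogen would separate them.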